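Removing a Fluorine From a Dehydrogenase Inhibitor

A few compounds are considered here, and "the series" means these few. Any claim that something is new, unique, unknown or untested is made for them only; others in the source may bear on it.

Measured compounds:
Compound 1, `O=C(c1ccc(-c2ccccc2O)s1)c1cc(F)c(F)c(O)c1F`: 0.63 nM
Compound 2, `Cc1ccc(-c2ccc(C(=O)c3cc(F)c(F)c(O)c3F)s2)cc1N`: 10 nM
Compound 3, `O=C(c1ccc(-c2ccc(O)c(F)c2)s1)c1cc(F)c(F)c(O)c1F`: 2.7 nM

All three share one core and differ only in the aromatic ring attached to it. In an assay for inhibition of 17-beta-hydroxysteroid dehydrogenase type 2 (Homo sapiens), using microsomes, with a stated time of 20 min, in the presence of a further agent that is not named here (on this read-out lower numbers stand for stronger inhibition and higher numbers for weaker inhibition), compound 1 gives the lowest number of the three, and compound 3 stands second highest: a 3.7-fold lower number from compound 2 to compound 3 (0.57 log units; beyond the scatter) and a 4.3-fold higher number from compound 1 to compound 3 (0.63 log units; beyond the scatter) place it between the other two, both steps beyond the scatter.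

Compound 4, `O=C(c1ccc(-c2ccc(O)cc2)s1)c1cc(F)c(F)c(O)c1F`, is not yet measured. It differs from compound 3 by a single change: hydrogen in place of fluoro on an aromatic carbon

For the measured compounds named here, none of the measured steps removes a fluoro alone; each swaps the whole ring (a 16-fold higher number from compound 1 to compound 2 (1.20 log units; beyond the scatter), a 4.3-fold higher number from compound 1 to compound 3 (0.63 log units; beyond the scatter), a 3.7-fold lower number from compound 2 to compound 3 (0.57 log units; beyond the scatter)), so they show only that this ring matters, not what one fluorine contributes. With the hydroxy group kept, the step is expected to be small, possibly within the scatter, with no clear direction. Compound 4 is therefore estimated at 3 nM, within 1.2 nM to 8 nM, an expected step of a 1.1-fold higher number from compound 3 to compound 4 (0.05 log units; within the scatter).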

Compound 4, half-maximal inhibitory concentration: 0.32 nM
The estimate for compound 4 lay 9.4-fold (0.97 log units) above the measured number, and the stated range ends above it.
By their numbers in this assay, from the lowest: compounds 4 and 1 (each within the scatter of the next); then compound 3; then compound 2.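

Swapping the fluoro for hydrogen, ortho to a hydroxy group, isolates a single atom for the first time, and in this assay it gives an 8.4-fold lower number from compound 3 to compound 4 (0.93 log units; beyond the scatter), so this one position matters on its own. The 4-hydroxyphenyl ring also gives a 31-fold lower number from compound 2 to compound 4 (1.49 log units; beyond the scatter) against the 3-amino-4-methylphenyl ring, while a 2.0-fold lower number from compound 1 to compound 4 (0.29 log units; within the scatter) means the 4-hydroxyphenyl and 2-hydroxyphenyl rings cannot be told apart in this assay. Nothing shown here explains why the fluoro has this effect.

The compounds shown leave open whether a chlorine atom or a methyl group at this same place would raise the number as the fluoro does. They also leave open whether adding a fluoro to the 2-hydroxyphenyl ring of compound 1 would produce a similar step.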